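Nitrile versus halogen on the fused core

The source may report more compounds than this note shows. Statements on the series, on what has been measured and on what is new or still open speak of the compounds shown alone.

Compound 1 `Fc1cc(-c2ccccc2C(F)(F)F)cc2nc(C3=NOC4(CCCCC4)C3)[nH]c12` gives 2.2 nM in a functional assay on HEK293 cells for antagonist activity at transient receptor potential M8 protein (Canis lupus familiaris), read by FLIPR and calcium flux; on this read-out higher numbers stand for weaker inhibition and lower numbers for stronger inhibition. Compound 2 `FC(F)(F)c1ccccc1-c1cc(Cl)c2[nH]c(C3=NOC4(CCCCC4)C3)nc2c1` gives 3.3 nM in this assay, and the swap between them is small: a 1.5-fold higher number from compound 1 to compound 2 (0.18 log units; within the scatter). Compound 3 `N#Cc1cc(-c2ccccc2C(F)(F)F)cc2nc(C3=NOC4(CCCCC4)C3)[nH]c12` gives 0.7 nM in this assay, the lowest of the three numbers, separated from both others by steps beyond the scatter: a 3.1-fold lower number from compound 1 to compound 3 (0.50 log units; beyond the scatter) and a 4.7-fold lower number from compound 2 to compound 3 (0.67 log units; beyond the scatter).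

Compound 4 `FC(F)(F)c1ccccc1-c1cc(Br)c2[nH]c(C3=NOC4(CCCCC4)C3)nc2c1` has not yet been measured in this assay. Relative to compound 3 the change is bromo in place of cyano on an aromatic carbon. Among the measured compounds shown here, the steps that bear on this run the other way, from a halogen to the nitrile, and each lowered the number: a 3.1-fold lower number from compound 1 to compound 3 (0.50 log units; beyond the scatter) and a 4.7-fold lower number from compound 2 to compound 3 (0.67 log units; beyond the scatter). Going back from the nitrile to a halogen is therefore expected to raise the number. Among the halogens measured, fluoro and chloro sit within the scatter of each other, a 1.5-fold higher number from compound 1 to compound 2 (0.18 log units; within the scatter); nothing here shows whether bromo follows chloro, but the two halogen compounds are the nearest reference points. The expected step is therefore modest and upward, a 5.0-fold higher number from compound 3 to compound 4 (0.70 log units; beyond the scatter). Compound 4 is estimated at 3.5 nM in this assay, with a range from 1.5 nM to 9 nM.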

Compound 4, half-maximal inhibitory concentration: 2.7 nM
Compound 4: the middle estimate sits 1.3-fold (0.11 log units) above what was measured; the measured number falls inside the stated range.
By their numbers in this assay, from the lowest: compound 3; then compounds 1, 4 and 2 (each within the scatter of the next).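

In this assay bromo joins fluoro and chloro as a third halogen on this aromatic carbon, ortho to a fused ring, and it cannot be told apart from either (a 1.2-fold lower number from compound 2 to compound 4 (0.09 log units; within the scatter)) or (a 1.2-fold higher number from compound 1 to compound 4 (0.09 log units; within the scatter)). The nitrile stands clear of bromo as well (a 3.9-fold higher number from compound 3 to compound 4 (0.59 log units; beyond the scatter)), so compound 3 now has steps beyond the scatter to all three halogen compounds and is the strongest inhibitor of the four, while the choice among these halogens leaves the number within the scatter. Nothing among the data shown accounts for this separation of the nitrile from the halogens.

Still open, going by these compounds, is whether the nitrile is alone in giving a lower number at this carbon, or whether a methoxy group, a primary amide, an amine or a carboxylic acid there would read with it or with the halogens. Also open, on these data alone, is whether the gap between nitrile and halogens persists when the 2-(trifluoromethyl)phenyl group or the spirocyclic cyclohexane end of the molecule is replaced by something else, such as a plain phenyl ring or a shorter alkyl chain.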